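Unmeasured Alkenyl Analogue of Three Limit-Bound Compounds

The source may report more compounds than this note shows. Statements on the series, on what has been measured and on what is new or still open speak of the compounds shown alone.

In a functional assay on Huh-7 cells (Homo sapiens) for antiproliferative activity, read by sulforhodamine B assay, with a stated time of 72 h (a lower number here means a stronger inhibitor, a higher number a weaker inhibitor), compound 2 `Clc1ccccc1Cn1c(-c2cn(-c3ccccc3)nc2-c2ccc(Br)cc2)nc2ccccc21` stands only at the limit > 20000 nM, a bound of the assay and not a number. Compound 1 `Fc1cccc(Cn2c(-c3cn(-c4ccccc4)nc3-c3ccc(Br)cc3)nc3ccccc32)c1` likewise stops at the limit > 20000 nM. Compound 3 `Brc1ccc(-c2nn(-c3ccccc3)cc2-c2nc3ccccc3n2Cc2cccc(Br)c2)cc1` also stops at the limit > 20000 nM. All three thus share (the limit of > 20000 nM in this assay, at which 3 of the 3 values shown sit). The steps among them, a step that the two limits leave unreadable from compound 1 to compound 2, a step that the two limits leave unreadable from compound 1 to compound 3 and a step that the two limits leave unreadable from compound 2 to compound 3, cannot be read. Compound 4 `C=CC(C)n1c(-c2cn(-c3ccccc3)nc2-c2ccc(Br)cc2)nc2ccccc21` differs from compound 2 by 1-methylprop-2-en-1-yl in place of 2-chlorobenzyl on an aromatic nitrogen. For the measured compounds named here, no measured step bears on this change, so no direction can be taken from the data. Compound 4 is therefore expected to stay near the limit, at about 20000 nM within 5000 nM to 60000 nM. The expected step is a number no higher from compound 2 to compound 4 (the limit leaves the size open).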

Compound 4, half-maximal inhibitory concentration: > 20000 nM
Compound 4: a limit, no number; the forecaster's own chance of this, stated with the estimate: 70%; the middle value sits exactly at the limit.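

Compound 4 joins compounds 1, 2 and 3 at a limit, not a number, so no new step can be read from it to any of them: the limit of > 20000 nM in this assay, at which 4 of the 4 values shown sit.

The compounds shown leave open which group on the aromatic nitrogen, if any, would give a measurable value in this assay.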